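Swapping the benzyl substituent on an adenosine-like scaffold

The source may hold more compounds than are shown below. What is called first, only, known or untested is meant among the compounds shown, and "the series" means these compounds.

Measured compounds:
compound 1, `OC[C@H]1O[C@@H](n2cnc3c(NCc4ccc(F)cc4)ncnc32)[C@H](O)[C@@H]1O`: 1200 nM
compound 2, `OC[C@H]1O[C@@H](n2cnc3c(NCc4ccc(Br)cc4)ncnc32)[C@H](O)[C@@H]1O`: 47400 nM

Compound 1 and compound 2 share one core and differ only in the substituent on the benzyl ring. In a functional assay on HL-60 cells (Homo sapiens) for antiproliferative activity, with a stated time of 72 h (a higher number here means a weaker inhibitor, a lower number a stronger inhibitor), compound 1 gives 1200 nM. Compound 2, with bromo in place of fluoro on an aromatic carbon, gives 47400 nM in this assay, which is a 40-fold higher number from compound 1 to compound 2 (1.60 log units; beyond the scatter). On these two numbers compound 2 stands highest, and its nearest neighbour is compound 1.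

Compound 3, `COc1ccccc1CNc1ncnc2c1ncn2[C@@H]1O[C@H](CO)[C@@H](O)[C@H]1O`, is not yet measured. Relative to compound 2 the change is 2-methoxyphenyl in place of 4-bromophenyl on a saturated chain carbon bound to a nitrogen on an aromatic ring. Among the compounds with values here, no measured step shows this particular exchange: the only step in hand, a 40-fold higher number from compound 1 to compound 2 (1.60 log units; beyond the scatter), swaps one halogen for another, so its size offers no direct guide to placing a methoxy group where the bromine stood. The direction of the new step in this assay is therefore open, and a wide range is appropriate. Compound 3 is expected to fall near 8000 nM, between 1500 nM and 45000 nM, which would amount to a 5.9-fold lower number from compound 2 to compound 3 (0.77 log units; beyond the scatter).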

Compound 3, half-maximal inhibitory concentration: 2300 nM
The estimate for compound 3 lay 3.5-fold (0.54 log units) above the measured number; the measured number falls inside the stated range.
By their numbers in this assay, from the lowest: compounds 1 and 3 (each within the scatter of the next); then compound 2.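

In this assay the place on the saturated chain carbon bound to a nitrogen on an aromatic ring proves able to carry a group other than a halogen: the exchange of 4-bromobenzyl for 2-methoxybenzyl gives a 21-fold lower number from compound 2 to compound 3 (1.31 log units; beyond the scatter) and shows that the poor number of compound 2 is not shared by every departure from 4-fluorophenyl. Set against the fluoro compound, the same group gives a 1.9-fold higher number from compound 1 to compound 3 (0.28 log units; within the scatter) and so leaves 4-fluorophenyl and 2-methoxyphenyl indistinguishable in this read-out, although the two rings differ in substituent and in where it sits. Nothing available explains why the bromo compound stands apart from the other two.

Because the exchange from compound 2 to compound 3 changes both the substituent and its place on the ring, the compounds shown cannot separate these two contributions, and 4-methoxybenzyl or 2-bromobenzyl would be needed to do so. Going by these compounds, whether an amine, a carboxylic acid or a longer chain at this place would keep the number of compound 1 and compound 3 also remains open.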